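Methylsulfanyl in place of cyclopropyl on the shared core

The source may hold more compounds than are shown below. What is called first, only, known or untested is meant among the compounds shown, and "the series" means these compounds.

In an in vitro ADME assay on microsomes from liver (Homo sapiens) for metabolic stability (a higher number here means faster removal of the compound, a lower number slower removal), compound 3 `Cc1cc(Nc2ccc(S(F)(F)(F)(F)F)cc2)n2nc(C3CC3)nc2n1` gives < 5 mL.min-1.g-1, which is a limit. Compound 2 `Cc1cc(Nc2ccc(S(F)(F)(F)(F)F)cc2)n2nc(C(F)(F)F)nc2n1` gives < 5 mL.min-1.g-1, also a limit. Among the compounds with values here, compound 1 `COCCc1nc2nc(C)cc(Nc3ccc(S(F)(F)(F)(F)F)cc3)n2n1` gives 11.5 mL.min-1.g-1, the only number in the set. Compound 4 `CSc1nc2nc(C)cc(Nc3ccc(S(F)(F)(F)(F)F)cc3)n2n1` carries methylsulfanyl in place of cyclopropyl on an aromatic carbon. Within the data shown here, no measured step involves methylsulfanyl. The nearest evidence is an at least 2.3-fold lower number from compound 1 to compound 2 (0.36 log units; beyond the scatter) and an at least 2.3-fold lower number from compound 1 to compound 3 (0.36 log units; beyond the scatter), both away from 2-methoxyethyl, while a step that the two limits leave unreadable from compound 2 to compound 3. Together they give only weak guidance, so a small rise in this assay is expected, close to the scatter: the estimate is an at least 1.2-fold higher number from compound 3 to compound 4 (0.07 log units; that floor lies within the scatter). Compound 4 is estimated at 6 mL.min-1.g-1, with an expected range from 3 mL.min-1.g-1 to 15 mL.min-1.g-1.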

Compound 4, intrinsic clearance in microsomes: 22.4 mL.min-1.g-1
Estimate against measurement, compound 4: 3.7-fold (0.57 log units) below; the measured number lies above the stated range.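

In this assay, the aromatic carbon between two ring nitrogen atoms proves sensitive to methylsulfanyl, with an at least 4.4-fold higher number from compound 3 to compound 4 (0.65 log units; beyond the scatter) and an at least 4.4-fold higher number from compound 2 to compound 4 (0.65 log units; beyond the scatter). Compound 2 and compound 3 each stand at a limit, so both steps give only a floor: the limit of < 5 mL.min-1.g-1 in this assay, at which 2 of the 4 values shown sit. Against 2-methoxyethyl the step is a 1.9-fold higher number from compound 1 to compound 4 (0.29 log units; within the scatter), so these two groups are not told apart here.

On these data alone, the step between trifluoromethyl and cyclopropyl cannot be read, so their order stays open. As far as these compounds go, how a methoxy or dimethylamino group would read at this position also stays open.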